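Replacing a Hydroxymethyl by a Vinyl Where All Values Sit at a Limit

This account rests on a few compounds, and the source may have more. Where it says the series, first, only, none or still open, it means among the compounds named here.

Compound 1 `[N-]=[N+]=N[C@H]1C[C@H](n2cnc3c(NCCO)nc(N)nc32)O[C@@H]1CO`: in an ADME assay on CCRF-CEM cells (Homo sapiens) for cytotoxicity, with a stated time of 5 days (a higher number here means a weaker inhibitor, a lower number a stronger inhibitor), compound 1 gives > 100000 nM, which is a limit of the assay and not a number.
Compound 2 `COc1nc(NC2CC2)c2ncn([C@H]3C[C@H](N=[N+]=[N-])[C@@H](CO)O3)c2n1`: in this assay compound 2 gives > 100000 nM, again a limit of the assay.
Compound 3 `COc1nc(Cl)nc2c1ncn2[C@H]1C[C@H](N=[N+]=[N-])[C@@H](CO)O1`: in this assay compound 3 gives > 100000 nM, also a limit of the assay.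

Compound 1 therefore stands where every measured compound stands: at the limit of > 100000 nM in this assay, at which 3 of the 3 values shown sit. Within the data shown here, no number separates it from compound 2 or compound 3, and no step between measured compounds can be read from these values, since all three are limits rather than numbers.

Compound 4 `C=CCNc1nc(N)nc2c1ncn2[C@H]1C[C@H](N=[N+]=[N-])[C@@H](CO)O1` has not yet been measured in this assay. It differs from compound 1 in one place: vinyl in place of hydroxymethyl on a saturated chain carbon bound to a nitrogen on an aromatic ring. Among the measured compounds shown here, no measured pair shows the effect of this change, so nothing among the measured values points to a step in either direction.

Given that compound 1 sits at a limit, the step from it to compound 4 is expected to be none beyond the scatter, a step that the limit leaves unreadable from compound 1 to compound 4. Compound 4 is accordingly estimated at 150000 nM in this assay, with a range from 40000 nM to 500000 nM, and it is most likely that the assay will again report only a limit for compound 4.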

Compound 4, half-maximal inhibitory concentration: > 100000 nM
Compound 4: no number, only a limit; the forecaster's own chance of this, stated with the estimate: 80%; the middle value does not contradict the limit.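

In this assay compound 4 gives > 100000 nM as a limit of the assay and not a number. Among these compounds, compound 1 also stands at a limit, so no step from compound 1 to compound 4 can be read. The compounds shown leave open what vinyl in place of hydroxymethyl does in this assay, for all of them stand at one limit: the limit of > 100000 nM in this assay, at which 4 of the 4 values shown sit.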